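This account rests on a few compounds, and the source may have more. Where it says the series, first, only, none or still open, it means among the compounds named here.

Compound 2 `Cc1cccc(C(=O)Nc2cccc(-c3oc4cc(-c5ccc(F)cc5)ccc4c(=O)c3O)c2)c1` gives 8030 nM in a functional assay on HCC1937 cells (Homo sapiens) for antiproliferative activity, read by CCK-8 assay, with a stated time of 72 h; a lower number here means a stronger inhibitor, a higher number a weaker inhibitor. Compound 1 `COc1ccccc1C(=O)Nc1cccc(-c2oc3cc(-c4ccc(F)cc4)ccc3c(=O)c2O)c1` gives 9050 nM in this assay, and a 1.1-fold lower number from compound 1 to compound 2 (0.05 log units; within the scatter) leaves the two within the scatter. Compound 3 `O=C(Nc1cccc(-c2oc3cc(-c4ccc(F)cc4)ccc3c(=O)c2O)c1)c1cccc(F)c1` carries fluoro in place of methyl on an aromatic carbon. Within the data shown here, only one measured step touches the same aryl group on the carbonyl, and that step, a 1.1-fold lower number from compound 1 to compound 2 (0.05 log units; within the scatter), barely moved the number, so a swap of methyl for fluoro at that position is expected to change little. For compound 3 the expected step is a 1.0-fold lower number from compound 2 to compound 3 (0.00 log units; within the scatter), nothing beyond the scatter. Compound 3 is therefore estimated at 8000 nM, with a range of 4000 nM to 16000 nM.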

Compound 3, half-maximal inhibitory concentration: 6590 nM
Estimate against measurement, compound 3: 1.2-fold (0.08 log units) above; the range from low to high includes it.
By their numbers in this assay, from the lowest: compounds 3, 2 and 1 (each within the scatter of the next).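

Fluoro in place of methyl gives a 1.2-fold lower number from compound 2 to compound 3 (0.09 log units; within the scatter) in this assay and 3-fluorophenyl in place of 2-methoxyphenyl gives a 1.4-fold lower number from compound 1 to compound 3 (0.14 log units; within the scatter) as the second new comparison. This position has thus now carried three different substituted phenyl groups with no step beyond the scatter, and fluoro joins methyl and methoxy among the groups tolerated at about the same level. Nothing measured here gives a reason for this result.

Still open, going by these compounds, is whether an amine, a carboxylic acid or a longer chain on this ring would shift the number beyond the scatter. The compounds shown also leave open how any change outside this ring would read.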